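Para-substituent swap on the hydrazide series

This account rests on a few compounds, and the source may have more. Where it says the series, first, only, none or still open, it means among the compounds named here.

The shared core carries an acetamido-substituted sulfonyl hydrazide linked to a second aromatic ring. Compound 1 `COc1ccc(NNS(=O)(=O)c2ccc(NC(C)=O)cc2)cc1` bears a methoxy group on that ring; compound 2 `CC(=O)Nc1ccc(S(=O)(=O)NNc2ccc(C(F)(F)F)cc2)cc1` bears a trifluoromethyl group in the same place. In an assay on HeLa cells for inhibition of Indoleamine 2,3-dioxygenase 1 (Homo sapiens), read by spectrophotometry, with a stated time of 24 h (on this read-out higher numbers stand for an effect only at larger amounts of compound and lower numbers for an effect already at smaller amounts), compound 1 gives only a limit, > 10000 nM. In this assay, among the measured compounds shown here, compound 2 gives 181 nM, the only real number in the set so far. The other entry, that of compound 1, is the limit (the limit of > 10000 nM in this assay, at which 1 of the 2 values shown sits). For the measured compounds named here, the step of an at least 55-fold lower number from compound 1 to compound 2 (1.74 log units; beyond the scatter) is the sole measured comparison available.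

Compound 3 `CC(=O)Nc1ccc(S(=O)(=O)NNc2ccc(F)cc2)cc1` differs from compound 2 in one place: fluoro in place of trifluoromethyl on an aromatic carbon. Going by the values given here, no measured step covers a fluoro group directly. The measured step shows that the substituent at this position matters strongly, and fluoro is smaller than trifluoromethyl, so a weakening step an 8.3-fold higher number from compound 2 to compound 3 (0.92 log units; beyond the scatter) is expected in this assay, though likely less severe than the loss seen with methoxy. Compound 3 is therefore estimated at 1500 nM, with a range from 300 nM to 8000 nM.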

Compound 3, half-maximal effective concentration: 609 nM
Estimate against measurement, compound 3: 2.5-fold (0.39 log units) above, and the stated range covers the measured number.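

In this assay, the second measured value at this position shows that activity does not depend on trifluoromethyl alone: fluoro in place of trifluoromethyl brings a 3.4-fold higher number from compound 2 to compound 3 (0.53 log units; beyond the scatter), a modest step that still lies beyond the scatter. Fluoro in place of methoxy brings an at least 16-fold lower number from compound 1 to compound 3 (1.21 log units; beyond the scatter), so both compounds with a fluorine-bearing group, compound 2 and compound 3, read far lower than the methoxy compound, and within this set the large gap separates methoxy from the other two groups. Compound 1 remains a limit and not a number, so the full size of each step from it stays unknown: the limit of > 10000 nM in this assay, at which 1 of the 3 values shown sits.

As far as these compounds go, whether the order of trifluoromethyl and fluoro extends to chloro, a nitrile or a plain hydrogen at this position remains open, as does whether an amine or a hydroxyl would read like methoxy. Three compounds varying in one place also leave open how these groups would read on any other part of the shared core.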